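Amide swap at the carbonyl: compound 2 to compound 3

This account rests on a few compounds, and the source may have more. Where it says the series, first, only, none or still open, it means among the compounds named here.

Measured in a functional assay on A549 cells (Homo sapiens) for inhibition, read by sulforhodamine B assay, with a stated time of 72 h; on this read-out lower numbers stand for stronger inhibition and higher numbers for weaker inhibition:
- compound 1 `CN1CCN(C(=O)c2c(N)sc(-c3ccc(Cl)cc3)c2-c2ccc(Cl)cc2)CC1`: 590 nM
- compound 2 `COc1ccc(CNC(=O)c2c(N)sc(-c3ccc(Cl)cc3)c2-c2ccc(Cl)cc2)cc1`: 18200 nM

Compound 2 holds the higher of the two numbers, at 18200 nM. Compound 3 `Nc1sc(-c2ccc(Cl)cc2)c(-c2ccc(Cl)cc2)c1C(=O)N1CCNCC1` has piperazin-1-yl in place of (4-methoxybenzyl)amino on a carbonyl carbon. Within the data shown here, the one measured step bearing on this change is a 31-fold higher number from compound 1 to compound 2 (1.49 log units; beyond the scatter), which is large, beyond the scatter, and introduces (4-methoxybenzyl)amino in place of 4-methylpiperazin-1-yl. The reverse direction is expected here, so a large step to a lower number is expected in this assay, an estimated 20-fold lower number from compound 2 to compound 3 (1.31 log units; beyond the scatter). For compound 3 the estimated value is 900 nM, with an expected range of 300 nM to 3000 nM.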

Compound 3, half-maximal inhibitory concentration: 1020 nM
Beside the measured number, compound 3's estimate is 1.1-fold (0.05 log units) below it; the range from low to high includes it.
By their numbers in this assay, from the lowest: compounds 1 and 3 (each within the scatter of the next); then compound 2.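

In this assay, piperazin-1-yl on the carbonyl carbon gives an 18-fold lower number from compound 2 to compound 3 (1.25 log units; beyond the scatter) and so restores most of what the (4-methoxybenzyl)amino group had lost, showing that the step also holds without the ring methyl. Hydrogen in place of methyl on the amine nitrogen in the ring gives a 1.7-fold higher number from compound 1 to compound 3 (0.24 log units; within the scatter) and leaves compound 1 and compound 3 indistinguishable here. No available measurement explains either step. Still open, as far as these compounds go, is whether morpholine or an open-chain amine such as 2-(dimethylamino)ethylamino on the carbonyl carbon would stay with compound 1 and compound 3 or fall toward compound 2.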